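Aryl swap at the oxazole-side position, compound 3 to 4

The compounds below may be only part of what the source reports. "The series", "measured", "known", "first", "only" and "open" are said of these compounds alone.

Values in a functional assay on HL-60 cells (Homo sapiens) for inhibition, read by MTT assay, with a stated time of 72 h; on this read-out lower numbers stand for stronger inhibition and higher numbers for weaker inhibition:
- compound 1 `Cc1nc(-c2ccccc2F)c(C(=O)N2CCN(c3cc(Cl)ccc3C)CC2)o1`: 229 nM
- compound 2 `Cc1nc(-c2ccc(F)cc2)c(C(=O)N2CCN(c3cccc(Cl)c3)CC2)o1`: 40.1 nM
- compound 3 `Cc1ccc(C)c(N2CCN(C(=O)c3oc(C)nc3-c3ccc(F)cc3)CC2)c1`: 358 nM
- compound 4 `Cc1ccc(C)c(N2CCN(C(=O)c3oc(C)nc3-c3ccccc3Cl)CC2)c1`: not yet measured

Compound 3 lies within the scatter of compound 1, and its number is clearly higher than that of compound 2. The next change is 2-chlorophenyl in place of 4-fluorophenyl on an aromatic carbon. Within the data shown here, the only measured step, an 8.9-fold higher number from compound 2 to compound 3 (0.95 log units; beyond the scatter), lies at the amine nitrogen, not at this place, so it shows only how far one swap can move the numbers in this assay. Among the measured compounds shown here, no measured step covers the present change, so no direction can be argued and no shift beyond the scatter is expected. The expected result is a 1.2-fold lower number from compound 3 to compound 4 (0.08 log units; within the scatter). For compound 4 the estimate is 300 nM, with an expected range of 100 nM to 900 nM.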

Compound 4, half-maximal inhibitory concentration: > 1000 nM
Compound 4: only a limit was reported (the forecaster's own chance of this, stated with the estimate: 3%); middle value at least 3.3-fold (0.52 log units) from the limit.
By their numbers in this assay, from the lowest: compound 2; then compounds 1 and 3 (each within the scatter of the next). At a limit, above all of these: compound 4.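

In this assay compound 4 gives > 1000 nM, which is a limit and not a number. The aryl group on the aromatic carbon next to the ring nitrogen is therefore not a silent place in this series: the swap of 4-fluorophenyl for 2-chlorophenyl gives an at least 2.7-fold higher number from compound 3 to compound 4 (0.44 log units; beyond the scatter). The only earlier step lay at the amine nitrogen, so this is the first measured shift at this position, and its full size stays unknown: the limit of > 1000 nM in this assay, at which 1 of the 4 values shown sits.

Going by these compounds, whether the step follows the halogen or its place on the phenyl ring remains open, since both change together. Also open, on these data alone, is how an amine or a carboxylic acid on this phenyl ring would read.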